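Removing the acetyl group from a brominated lactone

The compounds below may be only part of what the source reports. "The series", "measured", "known", "first", "only" and "open" are said of these compounds alone.

Compound 2 `CCC[C@@H](OC(C)=O)C1=C(Br)C(=C(Br)Br)OC1=O` was tested in a functional assay on Lu1 cells (Homo sapiens) for cytotoxicity (a lower number here means that less compound is needed, a higher number that more compound is needed for the effect), where compound 2 gives 1.1 ug/mL. Among the three compounds tested this is the lowest of the two numbers. Its closest neighbour is compound 1 `CCC[C@@H](OC(C)=O)C1=C(Br)/C(=C/Br)OC1=O`, which in this assay gives 1.7 ug/mL, a value within the scatter of compound 2, so the two cannot be ordered. Compound 3 `CCC[C@@H](OC(C)=O)C1=C(Br)[C@@](C)(OC)OC1=O` differs in its core and gives > 20 ug/mL, which is a limit of the assay rather than a number (the limit of > 20 ug/mL in this assay, at which 1 of the 3 values shown sits).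

Compound 4 `CCC[C@@H](O)C1=C(Br)C(=C(Br)Br)OC1=O` has not yet been measured. It differs from compound 2 in one place: hydrogen in place of acetyl on an oxygen on a saturated carbon. Among the compounds with values here, no pair of measured compounds shows this change, so its effect is open. The expectation is a step of a 1.8-fold higher number from compound 2 to compound 4 (0.26 log units; within the scatter), likely within the scatter or only slightly towards a higher number. In this assay compound 4 is therefore estimated to give 2 ug/mL, with a range from 0.7 ug/mL to 6 ug/mL.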

Compound 4, concentration for half-maximal effect: 1.7 ug/mL
For compound 4 the middle estimate is 1.2-fold (0.07 log units) above the measured one; low and high end bracket the measured number.
By their numbers in this assay, from the lowest: compounds 2, 1 and 4 (each within the scatter of the next). At a limit, above all of these: compound 3.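

In this assay, hydrogen in place of acetyl on an oxygen on a saturated carbon gives a 1.5-fold higher number from compound 2 to compound 4 (0.19 log units; within the scatter), which lies within the scatter, so in this pair the acetyl group is not required for the effect. Within the data shown here, all the earlier compounds carried the acetoxy group, so they could say nothing about this position, whereas this pair shows that the free hydroxy can stand there with no change beyond the scatter. Nothing measured here gives a cause for this step, and no measurement bears on it.

On these data alone, whether acetoxy to hydroxy behaves the same way on the core of compound 1 or the core of compound 3 remains open. Also open, as far as these compounds go, is what an amine, a methyl ether or a longer ester would give on this same carbon.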